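Dimethyl substitution on the imidazole of compound 1

This account rests on a few compounds, and the source may have more. Where it says the series, first, only, none or still open, it means among the compounds named here.

Compound 1 `CC(C)C(c1ncc[nH]1)c1ccc(-c2ccc3cccc(F)c3c2)[nH]c1=O` belongs to a set of three analogues of the shared core that differ only in the group on a saturated chain carbon bound to an aromatic carbon and a saturated chain carbon. In a functional assay on CHO cells for antagonist activity at prostaglandin E2 receptor EP3 subtype (Homo sapiens), read by cAMP accumulation (a higher number here means a weaker inhibitor, a lower number a stronger inhibitor), compound 1 gives 33 nM, the second highest of the three numbers. Compound 2 `CC(C)C(Nc1nccs1)c1ccc(-c2ccc3cccc(F)c3c2)[nH]c1=O` gives 10 nM, and compound 3 `CC(C)C(Cc1nnn[nH]1)c1ccc(-c2ccc3cccc(F)c3c2)[nH]c1=O` gives 134 nM. The steps measured so far are a 3.3-fold lower number from compound 1 to compound 2 (0.52 log units; beyond the scatter), a 4.1-fold higher number from compound 1 to compound 3 (0.61 log units; beyond the scatter) and a 13-fold higher number from compound 2 to compound 3 (1.13 log units; beyond the scatter); each of them exchanges the whole heteroaryl group or the link to it.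

Compound 4 `Cc1nc(C(c2ccc(-c3ccc4cccc(F)c4c3)[nH]c2=O)C(C)C)[nH]c1C` keeps the imidazole of compound 1 and carries methyl groups on it: 4,5-dimethyl-1H-imidazol-2-yl in place of 1H-imidazol-2-yl on a saturated chain carbon bound to an aromatic carbon and a saturated chain carbon. Among the measured compounds shown here, none of the measured steps bears directly on this change. For the measured compounds named here, they show only that the position tolerates exchange of the heteroaryl within a modest to large range, and no step tests substitution on the 1H-imidazol-2-yl ring itself. With the ring, the hydrogen-bond donor and the hydrogen-bond acceptor kept as counted, the expectation is a step not beyond the scatter, in either direction, namely a 1.1-fold higher number from compound 1 to compound 4 (0.03 log units; within the scatter). Compound 4 is therefore estimated at 35 nM in this assay, with a range from 10 nM to 120 nM.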

Compound 4, half-maximal inhibitory concentration: 50 nM
Beside the measured number, compound 4's estimate is 1.4-fold (0.15 log units) below it; the range from low to high includes it.
By their numbers in this assay, from the lowest: compound 2; then compounds 1 and 4 (each within the scatter of the next); then compound 3.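

In this assay, among the compounds shown here, the step of a 1.5-fold higher number from compound 1 to compound 4 (0.18 log units; within the scatter) is the first reading on substitution of the 1H-imidazol-2-yl ring itself, and it shows that 4,5-dimethyl-1H-imidazol-2-yl is accepted on this saturated chain carbon without a change beyond the scatter. The dimethyl compound also keeps a place among the other groups, with a 2.7-fold lower number from compound 3 to compound 4 (0.43 log units; beyond the scatter) on one side and a 5.0-fold higher number from compound 2 to compound 4 (0.70 log units; beyond the scatter) on the other, so the separation between these heteroaryl groups and links remains larger than anything the two methyl groups have produced so far. No supporting measurement accompanies these numbers, and the result can be recorded only as a tolerated change, with no cause attached.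

From the compounds shown here alone, it remains open whether a single methyl on the imidazole reads like the 4,5-dimethyl pair, and whether larger or different ring substituents, such as ethyl, trifluoromethyl, a carboxylic acid or an aminomethyl group, are accepted as well. Also open, going by these compounds, is how the imidazole behaves on an amine link of the kind carried by compound 2, which would separate the effect of the link from that of the ring.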